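Thiophene for fluorophenyl on the triazole carbon

This account rests on a few compounds, and the source may have more. Where it says the series, first, only, none or still open, it means among the compounds named here.

Of the compounds shown here, three carrying the hydroxamic acid head have been measured in an assay on Sf9 cells for inhibition of protein deacetylase HDAC6 (Homo sapiens), read by fluorescence, with a stated time of 40 min; a higher number here means a weaker inhibitor, a lower number a stronger inhibitor. Compound 1 `Cc1ccc(-c2nc(CNc3ccc(C(=O)NO)cc3)n(-c3ccccc3)n2)cc1` gives 224 nM; compound 2 `COc1ccc(-c2nc(CNc3ccc(C(=O)NO)cc3)n(-c3ccccc3)n2)cc1` gives 163 nM; compound 3 `O=C(NO)c1ccc(NCc2nc(-c3ccc(F)cc3)nn2-c2ccccc2)cc1` gives 115 nM. The steps among them, a 1.4-fold lower number from compound 1 to compound 2 (0.14 log units; within the scatter), a 1.9-fold lower number from compound 1 to compound 3 (0.29 log units; within the scatter) and a 1.4-fold lower number from compound 2 to compound 3 (0.15 log units; within the scatter), are all within the scatter, so compound 3 is not set apart from compound 1 or compound 2 on these numbers.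

Compound 4 `Cc1ccc(-c2nc(CNc3ccc(C(=O)NO)cc3)n(-c3ccccc3)n2)s1` differs from compound 3 by 5-methylthiophen-2-yl in place of 4-fluorophenyl on an aromatic carbon. Within the data shown here, none of the measured steps bears directly on this change: each of them exchanges one substituent on the phenyl ring that is now replaced as a whole, and each stayed within the scatter. There is thus no measured basis for a step beyond the scatter in either direction in this assay ; the expectation is for a number close to that of compound 3. The estimate means an expected step of a 1.3-fold higher number from compound 3 to compound 4 (0.12 log units; within the scatter). Compound 4 is therefore expected at 150 nM, within a range of 60 nM to 400 nM.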

Compound 4, half-maximal inhibitory concentration: 30.6 nM
The estimate for compound 4 lay 4.9-fold (0.69 log units) above the measured number; the whole stated range lies above it.
By their numbers in this assay, from the lowest: compound 4; then compounds 3, 2 and 1 (each within the scatter of the next).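

Exchanging the whole aromatic ring at this position moves the number in this assay beyond the scatter (a 3.8-fold lower number from compound 3 to compound 4 (0.57 log units; beyond the scatter); a 5.3-fold lower number from compound 2 to compound 4 (0.73 log units; beyond the scatter); a 7.3-fold lower number from compound 1 to compound 4 (0.86 log units; beyond the scatter)), which no substituent exchange on the phenyl ring did, and compound 4 is set apart from all three earlier compounds as the strongest of the four. Compound 1 and compound 4 both carry a methyl group on that ring, so their step goes with the change from a six-membered carbon ring to a five-membered ring holding sulfur, with the methyl group kept. Nothing shown explains the gain.

The compounds shown leave open whether the methyl group on the thiophene contributes, which an unsubstituted thiophen-2-yl would test. They also leave open whether sulfur itself matters, which a furan-2-yl or 5-methylfuran-2-yl group would address.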